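Rearranging two methoxy groups: compound 3 to compound 4

The compounds below may be only part of what the source reports. "The series", "measured", "known", "first", "only" and "open" are said of these compounds alone.

Three measured compounds share one core and differ only in the aryl group on a carbon with a double bond to nitrogen. Compound 1 `O=C(N/N=C/c1cccc(Cl)c1)c1cccnc1Nc1cccc(C(F)(F)F)c1` gives 77.8% in a functional assay on the whole organism (strain Wistar) for inhibition, with Rattus norvegicus as the target, read by paw edema, with a stated time of 30 min, at a dose of 10 mg/kg by the intraperitoneal route; on this read-out higher numbers stand for more inhibition at the one dose given (going by the name of the read-out) and lower numbers for less inhibition. Compound 2 `COc1ccc(/C=N/NC(=O)c2cccnc2Nc2cccc(C(F)(F)F)c2)cc1` gives 50.4%, and compound 3 `COc1ccc(/C=N/NC(=O)c2cccnc2Nc2cccc(C(F)(F)F)c2)c(OC)c1` gives 37.8%. Compound 3 stands lowest of the three, with compound 2 nearest to it and compound 1 furthest away. Every step points the same way: a number 27.4 percentage points lower from compound 1 to compound 2 (beyond the scatter), a number 40 percentage points lower from compound 1 to compound 3 (beyond the scatter), and a number 12.6 percentage points lower from compound 2 to compound 3 (beyond the scatter).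

Compound 4 `COc1ccc(/C=N/NC(=O)c2cccnc2Nc2cccc(C(F)(F)F)c2)cc1OC` has not yet been measured. It differs from compound 3 by 3,4-dimethoxyphenyl in place of 2,4-dimethoxyphenyl on a carbon with a double bond to nitrogen, the two holding the same atoms joined differently. Going by the values given here, no measured step moves a methoxy from one aromatic carbon to another, so guidance is indirect. The step from compound 2 to compound 3, in which a methoxy replaced hydrogen on an aromatic carbon, was modest, and both methoxy-bearing compounds sit well below compound 1. Because compound 3 gave 37.8% while carrying two methoxy groups, and compound 4 keeps both of them, a step of a number 4.2 percentage points higher from compound 3 to compound 4 (within the scatter) is expected, which lies within the scatter. Compound 4 is therefore estimated at 42%, with a range from 28% to 58%.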

Compound 4, a percentage reported as inhibition, in the whole organism at one dose (the size of the read-out at that dose, not a potency): 60.1%
Compound 4: middle estimate off by 18.1 percentage points, on the low side; the whole stated range lies below it.
By their numbers in this assay, from the lowest: compound 3; then compounds 2 and 4 (each within the scatter of the next); then compound 1.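

In this assay the arrangement of the two methoxy groups counts as well as their presence: with the same atoms on the carbon with a double bond to nitrogen, 3,4-dimethoxyphenyl in place of 2,4-dimethoxyphenyl gives a number 22.3 percentage points higher from compound 3 to compound 4 (beyond the scatter), so the two aryl groups are not interchangeable here. The earlier reading of a methoxy in place of hydrogen as a step downwards also no longer holds generally, since that change gives a number 12.6 percentage points lower from compound 2 to compound 3 (beyond the scatter) in one case and a number 9.7 percentage points higher from compound 2 to compound 4 (within the scatter) in the other, and its outcome therefore depends on which aromatic carbon carries the added group. The 3-chlorophenyl group still keeps the highest number in the series, with a number 17.7 percentage points lower from compound 1 to compound 4 (beyond the scatter), so the better of the two dimethoxyphenyl arrangements does not close the gap to compound 1.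

Nothing available explains why the two arrangements of the methoxy groups part in this way. From the compounds shown here alone, it also remains open how the 3,4-arrangement would fare with other groups, such as a hydroxy or a dimethylamino group, in place of the methoxy groups on the same ring.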